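Aryl ether exchange on the amine of compound 3

This account rests on a few compounds, and the source may have more. Where it says the series, first, only, none or still open, it means among the compounds named here.

Of the compounds shown here, three share one core and have been measured in a functional assay on MDA-MB-231 cells (Homo sapiens) for inhibition, read by MTT assay, with a stated time of 72 h, tested at 20 uM; a lower number here means less inhibition, a higher number more inhibition at the concentration tested (going by the name of the read-out). Compound 1 `CNC(=O)c1cc(Oc2ccc(Nc3nccc(N4CCCC4)n3)cc2)ccn1` gives 46.6%, and compound 2 `CNC(=O)c1cc(Oc2ccc(Nc3nccc(N4CCCCC4)n3)cc2)ccn1` gives 52.3%; the step of a number 5.7 percentage points higher from compound 1 to compound 2 (within the scatter) shows that the amine ring exchange at this position does not move the read-out beyond the scatter. Compound 3 `c1ccc2c(c1)CCN(c1ccnc(Nc3ccc(Oc4ncnc5sccc45)cc3)n1)C2` gives 26.8%, the lowest of the three numbers, set apart from compound 1 and from compound 2 by gaps beyond the scatter.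

Compound 4 `CNC(=O)c1cc(Oc2ccc(Nc3nccc(N4CCc5ccccc5C4)n3)cc2)ccn1` is not yet measured. Relative to compound 3 it carries a group of 10 heavy atoms (7 carbon, 2 nitrogen, 1 oxygen; one six-membered aromatic ring with 1 hetero atom) in place of a group of 9 heavy atoms (6 carbon, 2 nitrogen, 1 sulfur; one five-membered aromatic ring with 1 hetero atom, one six-membered aromatic ring with 2 hetero atoms), on an oxygen on an aromatic ring. Going by the values given here, no measured step covers this exchange directly: the single step on record concerns the amine ring, not the aryl ether, so its size offers no guidance here. Compound 4 combines the aryl ether found in compound 1 and compound 2 with the amine portion of compound 3, and the weak result of compound 3 cannot be assigned to one or the other part on these data. The estimate for compound 4 is therefore placed between the two groups, expected at 40% with a range of 22% to 58%. The step this implies, a number 13.2 percentage points higher from compound 3 to compound 4 (beyond the scatter), is expected to be upward and near the edge of the scatter, with wide uncertainty.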

Compound 4, a percentage reported as inhibition, at one concentration (the size of the read-out at that concentration, not a potency): 41.2%
Estimate against measurement, compound 4: 1.2 percentage points below, and the stated range covers the measured number.
By their numbers in this assay, from the lowest: compound 3; then compounds 4, 1 and 2 (each within the scatter of the next, the first and the last beyond it).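

In this assay, going by these compounds alone, the exchange on the oxygen on an aromatic ring, with the 1,2,3,4-tetrahydroisoquinolin-2-yl amine held fixed, gives a number 14.4 percentage points higher from compound 3 to compound 4 (beyond the scatter) and so shows for the first time that the group on this oxygen alone can move the read-out, though the single pair says nothing about other amines. Within the data shown here, with 2-(methylcarbamoyl)pyridin-4-yl held fixed, 1,2,3,4-tetrahydroisoquinolin-2-yl in place of piperidin-1-yl gives a number 11.1 percentage points lower from compound 2 to compound 4 (beyond the scatter) and so provides the first amine exchange beyond the scatter, whereas the same group in place of pyrrolidin-1-yl gives a number 5.4 percentage points lower from compound 1 to compound 4 (within the scatter) and goes against any general effect of this amine. No supporting data are available to explain these steps.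

As far as these compounds go, whether the aryl ether exchange keeps its size and direction with pyrrolidin-1-yl or piperidin-1-yl on the aromatic carbon remains open, as does the effect of a morpholin-4-yl ring or an open-chain dimethylamino group there. Also open, from the compounds shown here alone, is what a carboxylic acid or a primary amide in place of the methylcarbamoyl group would do to the read-out at this single concentration.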